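Amino for chloro on a dichloropurine scaffold

The source may report more compounds than this note shows. Statements on the series, on what has been measured and on what is new or still open speak of the compounds shown alone.

Compound 1 `ClCc1cccc(Cn2cnc3c(Cl)nc(Cl)nc32)c1`: 6310 nM
Compound 2 `ClCc1cccc(Cn2cnc3nc(Cl)nc(Cl)c32)c1`: 3090 nM

In a functional assay on NCI-H460 cells (Homo sapiens) for cytotoxicity, read by sulforhodamine B assay, with a stated time of 48 h (a lower number here means a stronger inhibitor of growth, a higher number a weaker inhibitor of growth), compound 1 gives 6310 nM, the highest of the two numbers. Compound 2, which gives 3090 nM, lies a step beyond the scatter below it. Compound 3 `Nc1nc(Cl)c2ncn(Cc3cccc(CCl)c3)c2n1` has not yet been measured. It differs from compound 1 in one place: amino in place of chloro on an aromatic carbon, the place being on an aromatic carbon of a six-membered aromatic ring with two nitrogens, between two ring nitrogen atoms. Going by the values given here, no measured pair isolates this change, so the step is expected to be modest, likely none beyond the scatter, at a 1.3-fold higher number from compound 1 to compound 3 (0.10 log units; within the scatter). Compound 3 is estimated at 8000 nM, within 2500 nM to 25000 nM.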

Compound 3, concentration for total growth inhibition: 15900 nM
Beside the measured number, compound 3's estimate is 2.0-fold (0.30 log units) below it; measured number inside the range.
By their numbers in this assay, from the lowest: compound 2; then compound 1; then compound 3.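

In this assay, going by these compounds alone, amino in place of chloro on an aromatic carbon, between two ring nitrogen atoms, gives the first single-place step in this set, a 2.5-fold higher number from compound 1 to compound 3 (0.40 log units; beyond the scatter). At this position, then, the swap makes the compound a weaker inhibitor of growth, so amino does not stand in for chloro here. No available evidence accounts for this step.

On these data alone, it remains open how a methylamino or methoxy group would fare at this position. Also open, as far as these compounds go, is whether amino would give a similar step on the core of compound 2.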